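This account rests on a few compounds, and the source may have more. Where it says the series, first, only, none or still open, it means among the compounds named here.

In a functional assay on DU-145 cells (Homo sapiens) for inhibition, read by MTT assay, with a stated time of 48 h (on this read-out lower numbers stand for stronger inhibition and higher numbers for weaker inhibition), compound 1 `Cn1c(/C=C2\SC(=O)N(CC(=O)N3CCOCC3)C2=O)nc2ccccc21` gives 41100 nM and compound 3 `CCn1c(/C=C2\SC(=O)N(CC(=O)N3CCCC3)C2=O)nc2ccccc21` gives 45100 nM so that the two lie within the scatter of each other. Compound 2 `Cn1c(/C=C2\SC(=O)N(CC(=O)N3CCCCC3)C2=O)nc2ccccc21` shows > 50000 nM as a limit of the assay. Compound 4 `Cn1c(/C=C2\SC(=O)N(CC(=O)N3CCCC3)C2=O)nc2ccccc21` arises from compound 3 by hydrogen in place of methyl on a saturated chain carbon bound to an aromatic nitrogen with hydrogen in place of methyl on a saturated chain carbon bound to an aromatic nitrogen, which turns ethyl to methyl. Going by the values given here, no measured step touches that place. The only one, an at least 1.2-fold higher number from compound 1 to compound 2 (0.08 log units; that floor lies within the scatter) with piperidin-1-yl in place of morpholin-4-yl on a carbonyl carbon, has a floor within the scatter and ends at the limit of > 50000 nM in this assay, at which 1 of the 3 values shown sits, so it sets no size here. In this assay no step beyond the scatter is therefore expected, and the estimated step is a 1.0-fold lower number from compound 3 to compound 4 (0.00 log units; within the scatter) for this change. Compound 4 is expected at 45000 nM within a range of 25000 nM to 80000 nM and may also read only as a limit.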

Compound 4, half-maximal inhibitory concentration: > 50000 nM
Compound 4 ended at the assay's limit; the forecaster's own chance of this, stated with the estimate: 40%; middle value at least 1.1-fold (0.04 log units) away from the limit.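

In this assay, going by these compounds alone, there is an at least 1.1-fold higher number from compound 3 to compound 4 (0.04 log units; that floor lies within the scatter) for hydrogen in place of methyl on a saturated chain carbon bound to an aromatic nitrogen, the first reading at this place, and it gives only a floor. There is also an at least 1.2-fold higher number from compound 1 to compound 4 (0.08 log units; that floor lies within the scatter) when the group on the carbonyl carbon changes from morpholin-4-yl to pyrrolidin-1-yl, while the step between compound 2 and compound 4 cannot be read. Neither floor sets a size, and the limit now weighs more: the limit of > 50000 nM in this assay, at which 2 of the 4 values shown sit. The compounds shown leave open whether a longer chain such as propyl at this place, or a chain ending in an amine or a carboxylic acid, would give a step beyond the scatter.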